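Cytotoxicity notes: aryl swap on the aminomethyl side chain

A few compounds are considered here, and "the series" means these few. Any claim that something is new, unique, unknown or untested is made for them only; others in the source may bear on it.

Measured in an ADME assay on cells (Homo sapiens) for cytotoxicity, read by polymerase chain reaction, with a stated time of 3 days; a higher number here means that more compound is tolerated, a lower number that less compound is tolerated:
compound 1 `Cc1nc(NC(C)C)nc(N[C@@H]2C[C@H](CO)[C@@H](O)[C@H]2O)c1-c1nc2ccccc2s1` gives 13000 nM
compound 2 `Cc1nc(NCC2CCC2)nc(N[C@@H]2C[C@H](CO)[C@@H](O)[C@H]2O)c1-c1nc2ccccc2s1` gives a limit of the assay, > 25000 nM
compound 3 `Cc1nc(NCc2ccccc2)nc(N[C@@H]2C[C@H](CO)[C@@H](O)[C@H]2O)c1-c1nc2ccccc2s1` gives 9000 nM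

Compound 3 holds the lowest of the two numbers; its nearest neighbour is compound 1, and the step of a 1.4-fold lower number from compound 1 to compound 3 (0.16 log units; within the scatter) lies within the scatter. One of the three values sits at the limit of > 25000 nM in this assay, at which 1 of the 3 values shown sits, and is a limit only.

Compound 4 `Cc1nc(NCc2cccs2)nc(N[C@@H]2C[C@H](CO)[C@@H](O)[C@H]2O)c1-c1nc2ccccc2s1` differs from compound 3 by thiophen-2-yl in place of phenyl on a saturated chain carbon bound to a nitrogen on an aromatic ring. Among the compounds with values here, the only measured step at this position is an at least 2.7-fold lower number from compound 2 to compound 3 (0.44 log units; beyond the scatter), where a saturated ring gave way to an aromatic one. Here one aromatic ring replaces another, so no step beyond the scatter is expected: no change at the digits printed from compound 3 to compound 4 (within the scatter). Compound 4 is estimated at 9000 nM, expected between 4500 nM and 20000 nM.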

Compound 4, half-maximal cytotoxic concentration: 6000 nM
Compound 4: the middle estimate sits 1.5-fold (0.18 log units) above what was measured; measured number inside the range.
By their numbers in this assay, from the lowest: compounds 4, 3 and 1 (each within the scatter of the next, the first and the last beyond it). At a limit, above all of these: compound 2.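

In this assay, one aromatic ring replacing another on this saturated chain carbon leaves the number within the scatter (a 1.5-fold lower number from compound 3 to compound 4 (0.18 log units; within the scatter)). Unlike benzyl, (thiophen-2-yl)methyl in place of isopropyl gives a step beyond the scatter (a 2.2-fold lower number from compound 1 to compound 4 (0.34 log units; beyond the scatter)). The step from the saturated ring is also beyond the scatter (an at least 4.1-fold lower number from compound 2 to compound 4 (0.61 log units; beyond the scatter)), but compound 2 holds only a limit: (the limit of > 25000 nM in this assay, at which 1 of the 4 values shown sits).

Still open, from the compounds shown here alone, is how a pyridinylmethyl group or a longer chain such as phenethyl on this nitrogen would read in this assay.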